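A few compounds are considered here, and "the series" means these few. Any claim that something is new, unique, unknown or untested is made for them only; others in the source may bear on it.

Measured compounds:
- compound 1 `O=S(=O)(NCCNCc1cccc2ccccc12)c1cc(C(F)(F)F)cc(C(F)(F)F)c1`: 21000 nM
- compound 2 `O=S(=O)(NCCCNCc1ccccc1Cl)c1cc(C(F)(F)F)cc(C(F)(F)F)c1`: 9300 nM
- compound 3 `COc1ccc(CNCCCNS(=O)(=O)c2cc(C(F)(F)F)cc(C(F)(F)F)c2)cc1OC`: 3800 nM

All three share one core, a sulfonamide carrying two trifluoromethyl groups, joined through an amine to a benzyl-type group, and all were tested in a functional assay on A2780 cells (Homo sapiens) for inhibition, read by MTT assay, with a stated time of 72 h; on this read-out higher numbers stand for weaker inhibition of growth and lower numbers for stronger inhibition of growth. Compound 1 gives the highest number of the three, so it is the weakest inhibitor of growth here; compound 2 comes nearest, and compound 3 lies furthest away with the lowest number.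

The new compound 4 `CC(C)(C)c1ccc(CNCCNS(=O)(=O)c2cc(C(F)(F)F)cc(C(F)(F)F)c2)cc1` differs from compound 1 in one place only: 4-(tert-butyl)phenyl in place of naphthalen-1-yl on a saturated chain carbon bound to an amine nitrogen. Within the data shown here, the only measured step that bears on this kind of change is the swap of one aryl group for another at the same place, a 2.4-fold lower number from compound 2 to compound 3 (0.39 log units; beyond the scatter). That step was modest, and it says nothing about a tert-butyl-bearing ring in particular. The expectation for compound 4 is therefore a step of similar, modest size, most likely toward a lower number, a 1.8-fold lower number from compound 1 to compound 4 (0.24 log units; within the scatter). On that basis compound 4 is estimated at 12000 nM, with a likely range from 4000 nM to 35000 nM.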

Compound 4, concentration for 50% growth inhibition: 14000 nM
Estimate against measurement, compound 4: 1.2-fold (0.07 log units) below, within the range that was stated.
By their numbers in this assay, from the lowest: compound 3; then compounds 2, 4 and 1 (each within the scatter of the next, the first and the last beyond it).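

In this assay, the two-ring naphthalen-1-yl gives way to the one-ring 4-(tert-butyl)phenyl, which has the same number of heavy atoms, with a 1.5-fold lower number from compound 1 to compound 4 (0.18 log units; within the scatter). This shows that, on a saturated chain carbon bound to an amine nitrogen, this exchange of one aryl group for another leaves the number within the usual scatter, whereas the earlier exchange gave a 2.4-fold lower number from compound 2 to compound 3 (0.39 log units; beyond the scatter), beyond the scatter. No measurement at hand offers an explanation for this result.

On these data alone, it remains open whether 3,4-dimethoxyphenyl, seen here only in compound 3, would lower the number on the chain shared by compound 1 and compound 4. As far as these compounds go, how a carboxylic acid or an amine in place of the tert-butyl group of compound 4 would behave also stays open.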